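This account rests on a few compounds, and the source may have more. Where it says the series, first, only, none or still open, it means among the compounds named here.

In a functional assay on A2780 cells (Homo sapiens) for inhibition, read by WST assay, with a stated time of 72 h (on this read-out higher numbers stand for weaker inhibition and lower numbers for stronger inhibition), compound 1 `N#C/N=C(\NCCCCCCC(=O)NOC1CCCCC1)Nc1ccncc1`, which bears only hydrogen on the saturated chain carbon bound to the carbonyl carbon, gives 35 nM. Compound 2 `C[C@@H](CCCCCN/C(=N\C#N)Nc1ccncc1)C(=O)NOC1CCCCC1`, with methyl on that carbon, gives 0.08 nM, and compound 3 `N#C/N=C(\NCCCCC[C@@H](Cc1ccccc1)C(=O)NOC1CCCCC1)Nc1ccncc1`, with benzyl there, gives 0.32 nM. Compound 3 thus holds the middle place of the three: its number is higher than that of compound 2 and far lower than that of compound 1.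

The next compound is compound 4 `N#C/N=C(\NCCCCC[C@H](Cc1ccccc1)C(=O)NOC1CCCCC1)Nc1ccncc1`, and the change is this: the two compounds have the same atoms and bonds and differ only in configuration as drawn: 1 of 2 stereo elements differ; a stereocentre at a saturated chain carbon is drawn S in compound 3 and R in compound 4. The benzyl group stays, and only its configuration as drawn is different. For the measured compounds named here, two measured steps bear on this carbon, a 440-fold lower number from compound 1 to compound 2 (2.64 log units; beyond the scatter) and a 110-fold lower number from compound 1 to compound 3 (2.04 log units; beyond the scatter). Going by the values given here, both are large and show that this position can matter greatly, but each replaces hydrogen, and no measured pair here differs in configuration alone. The size of an inversion is therefore not known, and neither direction is favoured by the data. The central expectation is no step beyond the scatter, with wide margins on both sides. The expected step is a 1.3-fold higher number from compound 3 to compound 4 (0.10 log units; within the scatter). For compound 4 the estimated value is 0.4 nM, with an expected range from 0.05 nM to 5 nM.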

Compound 4, half-maximal inhibitory concentration: 0.22 nM
Estimate against measurement, compound 4: 1.8-fold (0.26 log units) above; the range from low to high includes it.
By their numbers in this assay, from the lowest: compound 2; then compounds 4 and 3 (each within the scatter of the next); then compound 1.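

In this assay, for the compounds shown here, this pair gives the first reading of configuration alone at this carbon, and a 1.5-fold lower number from compound 3 to compound 4 (0.16 log units; within the scatter) shows that inverting the benzyl-bearing centre leaves the number within the scatter, a reading that rests on one plain fact: the fact that compounds 3 and 4 differ only in the configuration as drawn. The large gain over the unsubstituted chain of compound 1 is therefore not tied to one drawn configuration of the benzyl group, as both a 110-fold lower number from compound 1 to compound 3 (2.04 log units; beyond the scatter) and a 160-fold lower number from compound 1 to compound 4 (2.20 log units; beyond the scatter) are large. Exchanging the substituent matters far less than placing one on this carbon at all, for the change from methyl to benzyl gives a 2.8-fold higher number from compound 2 to compound 4 (0.44 log units; beyond the scatter), a modest step that is beyond the scatter but small beside the steps from compound 1.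

Whether the methyl compound would tolerate inversion in the same way stays open, as the only configuration pair shown carries benzyl. Also open, on these data alone, is what an ethyl group, a hydroxyl group or an amine on this carbon would give, and whether any of them would make the two configurations differ beyond the scatter.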